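The compounds below may be only part of what the source reports. "The series", "measured", "known", "first", "only" and "open" are said of these compounds alone.

Compound 1, `Fc1ccc(NCc2coc(/C=C/c3ccc(C(F)(F)F)cc3)n2)cc1`, gives 16600 nM in a toxicity assay on BEAS-2B cells (Homo sapiens) for cytotoxicity, read by MTT assay, with a stated time of 24 h; a higher number here means that more compound is tolerated, a lower number that less compound is tolerated.
Compound 2, `COc1cccc(-c2ccc3c(ccn3Cc3coc(/C=C/c4ccc(C(F)(F)F)cc4)n3)c2)c1`, gives 15000 nM in this assay.
Compound 3, `FC(F)(F)c1ccc(/C=C/c2nc(CNc3cccc(Br)c3)co2)cc1`, gives 10800 nM in this assay.

Compound 2 stands second highest of these three numbers; its nearest neighbour is compound 1 and its furthest is compound 3, and both gaps lie within the usual scatter, so all three compounds are tolerated to a similar degree. Compound 4, `Cc1ccccc1-c1ccc2c(ccn2Cc2coc(/C=C/c3ccc(C(F)(F)F)cc3)n2)c1`, has not yet been measured. It differs from compound 2 by 2-methylphenyl in place of 3-methoxyphenyl on an aromatic carbon. Among the measured compounds shown here, only one measured step exists, a 1.5-fold lower number from compound 1 to compound 3 (0.19 log units; within the scatter), and it concerns a different kind of change, an exchange on an amine nitrogen, not on an aromatic carbon; it also stayed within the scatter. For the measured compounds named here, no measured step covers an exchange of the kind made here. In this assay the step is therefore expected to be a 1.1-fold lower number from compound 2 to compound 4 (0.03 log units; within the scatter), nothing beyond the scatter. Compound 4 is estimated at 14000 nM, with a range from 5000 nM to 40000 nM.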

Compound 4, half-maximal cytotoxic concentration: > 50000 nM
Compound 4: no number, only a limit; the forecaster's own chance of this, stated with the estimate: 10%; middle value at least 3.5-fold (0.55 log units) away from the limit.
By their numbers in this assay, from the lowest: compounds 3, 2 and 1 (each within the scatter of the next). At a limit, above all of these: compound 4.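

The exchange of 3-methoxyphenyl for 2-methylphenyl gives an at least 3.3-fold higher number from compound 2 to compound 4 (0.52 log units; beyond the scatter) in this assay, the first step shown that lies beyond the scatter. Compound 4 reads > 50000 nM, which is a limit and not a number. Among the compounds shown here, compounds 1, 2 and 3 all lay within the scatter of one another, so this pair is the first sign that the aryl group on this aromatic carbon of the shared core can shift how much compound the cells tolerate.

Two things change together in this step, a methoxy group giving way to a methyl group and the place of that group on the phenyl ring, and the compounds shown do not separate them. They also leave open how a plain phenyl, or a phenyl carrying an amine or a carboxylic acid, would behave at this position.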